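Swapping a carbamate for a branched amide in an indazole series

The source may hold more compounds than are shown below. What is called first, only, known or untested is meant among the compounds shown, and "the series" means these compounds.

Measured compounds:
- compound 1, `CCCCC(CC)C(=O)Nc1ccc2ccn(Cc3ccc(C(=O)NS(=O)(=O)c4ccccc4)cc3OC)c2c1`: 8.6
- compound 2, `COc1cc(-c2nn[nH]n2)ccc1Cn1ncc2ccc(NC(=O)OC3CCCC3)cc21`: 7.7
- compound 3, `COc1cc(C(=O)NS(=O)(=O)c2ccccc2N)ccc1Cn1ccc2ccc(NC(=O)CC3CCCC3)cc21`: 9.9

All three were tested in a functional assay (trachea) for antagonist activity, with Cavia porcellus as the target; a lower number here means a less potent compound, a higher number a more potent compound, by a factor of ten per unit of this negative logarithm. Compound 2 stands lowest of the three: compound 1 sits higher by a margin beyond the scatter, and compound 3 higher still, also beyond the scatter.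

The unmeasured compound 4, `CCCCC(CC)C(=O)Nc1ccc2cnn(Cc3ccc(-c4nn[nH]n4)cc3OC)c2c1`, is built from compound 2 by one change: 1-ethylpentyl in place of cyclopentyloxy on a carbonyl carbon. Because compound 1 also carries ((1-ethylpentyl)carbonyl)amino on its core and gives 8.6, the step in this assay is expected to run upward, by a moderate amount rather than none. Among the measured compounds shown here, no directly comparable pair of measured compounds shows this exact swap, so the size is uncertain, and compound 1 differs from compound 4 in other places as well. The expected step of a number 0.50 log units higher from compound 2 to compound 4 (beyond the scatter) rests on that single comparison. Compound 4 is therefore estimated at 8.2, with a likely range from 7.5 to 8.9.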

Compound 4, negative logarithm of the antagonist equilibrium constant: 7.1
Compound 4: middle estimate off by 1.10 log units, on the high side, outside the stated range (below it).
By their numbers in this assay, from the lowest: compound 4; then compound 2; then compound 1; then compound 3.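

Putting 1-ethylpentyl in place of cyclopentyloxy on a carbonyl carbon gives a number 0.60 log units lower from compound 2 to compound 4 (beyond the scatter) in this assay. This is the first pair shown that differs in one place only, so it is the first direct sign that the group on this carbonyl carbon affects potency, and on this core the open-chain amide falls below the ring-bearing carbamate. No measurement shown here accounts for the drop.

The swap removes the ring and the oxygen together, so their separate contributions cannot be told apart; a cyclopentyl group placed directly on the carbonyl carbon, or a pentyloxy chain in the same place, would pull them apart. From the compounds shown here alone, whether the same swap runs in the same direction on the cores of compound 1 and compound 3 also remains open.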